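The compounds below may be only part of what the source reports. "The series", "measured", "known", "first", "only" and "open" are said of these compounds alone.

Notes on the series. Compound 1 `Cc1cn(C2COCO2)c(=O)[nH]c1=O` carries a methyl on the shared core with a dioxolane ring on the ring nitrogen. In a functional assay on Vero cells (Chlorocebus sabaeus) for cytotoxicity (on this read-out lower numbers stand for stronger inhibition and higher numbers for weaker inhibition), compound 1 gives > 100000 nM, which is a limit of the assay and not a number. Compound 2 `O=c1ccn([C@@H]2CO[C@@H](CO)O2)c(=O)[nH]1` has the unsubstituted core and a hydroxymethyl on the dioxolane ring. In this assay compound 2 gives > 100000 nM, again only a limit of the assay. Going by the values given here, compound 2 therefore stands on (the limit of > 100000 nM in this assay, at which 2 of the 2 values shown sit); both values shown sit there, and no step between measured compounds can be read from them.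

Compound 3 `O=c1ccn([C@H]2CO[C@@H](CO)O2)c(=O)[nH]1` is the next member. The change from compound 2 to compound 3 is the two compounds have the same atoms and bonds and differ only in configuration as drawn: 1 of 2 stereo elements differ; a stereocentre at a saturated ring carbon is drawn S in compound 2 and R in compound 3; nothing leaves and nothing enters. With the same atoms and bonds and only one stereocentre redrawn, no step beyond the scatter is expected in this assay in either direction, so the expectation is that compound 3 remains at the limit like compound 2 with > 100000 nM. Compound 3 is thus expected to give 100000 nM, within 50000 nM to 300000 nM, and the step from compound 2 to compound 3 is estimated as a number no higher from compound 2 to compound 3 (the limit leaves the size open).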

Compound 3, half-maximal inhibitory concentration: > 100000 nM
Compound 3 ended at the assay's limit (the forecaster's own chance of this, stated with the estimate: 85%); the middle value lies on the limit itself.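

In this assay compound 3 gives > 100000 nM, a limit of the assay and not a number. No step from compound 2 to compound 3 can be read, as both compounds sit at the same limit: the limit of > 100000 nM in this assay, at which 3 of the 3 values shown sit.

The compounds shown leave open whether the redrawn stereocentre at the saturated ring carbon has any effect on this read-out.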